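The source may hold more compounds than are shown below. What is called first, only, known or untested is meant among the compounds shown, and "the series" means these compounds.

Within the data shown here, in an ADME assay on microsomes from liver (Homo sapiens) for metabolic stability, using NADPH, with a stated time of 40 min, tested at 2 uM (a higher number here means that the compound lasts longer, a lower number that the compound disappears faster), two compounds have numbers so far. Compound 1 `Clc1cccc2c(-c3ccc4ccccc4n3)c[nH]c12` gives 0.283 h as its half-life, while compound 2 `Clc1cc(Cl)c2[nH]cc(-c3ccc4ccccc4n3)c2c1` gives 2.57 h as its half-life, the highest of the two numbers and beyond the scatter from compound 1. Compound 3 `Cc1cc(Cl)c2[nH]cc(-c3ccc4ccccc4n3)c2c1` has not yet been measured. It departs from compound 2 through methyl in place of chloro on an aromatic carbon with methyl in place of chloro on an aromatic carbon. Among the measured compounds shown here, the only measured step that bears on this change is a 9.1-fold higher number from compound 1 to compound 2 (0.96 log units; beyond the scatter) with chloro in place of hydrogen on an aromatic carbon. The chloro gained in that step is the one that leaves, so compound 3 is expected to give back part of that gain. For the measured compounds named here, no measured step involves methyl, which leaves the size of the loss uncertain. A drop of moderate size is expected, smaller than the earlier gain, and the estimated change is a 2.6-fold lower number from compound 2 to compound 3 (0.41 log units; beyond the scatter) in this assay. For compound 3 the estimated half-life is 1 h with an expected range from 0.35 h to 2.8 h in this assay once it is measured.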

Compound 3, half-life: 0.3 h
The estimate for compound 3 lay 3.3-fold (0.52 log units) above the measured number; measured number outside the range, below it.
By their numbers in this assay, from the lowest: compounds 1 and 3 (each within the scatter of the next); then compound 2.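

With methyl now in the place para to a fused ring, this assay has three groups to compare there, and the earlier compounds had shown only that chloro gave a longer half-life than hydrogen in a 9.1-fold higher number from compound 1 to compound 2 (0.96 log units; beyond the scatter) for that one change. The new result shows that this gain does not extend to another group of one heavy atom: the change to methyl gives an 8.6-fold lower number from compound 2 to compound 3 (0.93 log units; beyond the scatter) and so removes the gain, while a 1.1-fold higher number from compound 1 to compound 3 (0.03 log units; within the scatter) leaves methyl indistinguishable from hydrogen at this place, so that among these three groups only chloro stands apart. Nothing available bears on what separates chloro from methyl here.

The compounds shown leave open whether the longer half-life is particular to chloro or would also appear with fluoro, bromo, trifluoromethyl, methoxy or a nitrile at this place. They also leave open how much the chloro group shared by all three compounds contributes, and whether the effect of chloro at this place would persist if that shared group were replaced by hydrogen or methyl.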